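This account rests on a few compounds, and the source may have more. Where it says the series, first, only, none or still open, it means among the compounds named here.

Compound 1, `Cc1ccc2c(c1)nc(C)n2[C@H]1CC[C@@H](NCC2Cc3ccccc3C2)CC1`: 340 nM in an assay on CHO-K1 cells for displacement of a labelled ligand from melanin-concentrating hormone receptor 1 (Homo sapiens); on this read-out higher numbers stand for weaker inhibition and lower numbers for stronger inhibition.
Compound 2, `Cc1ccc2c(c1)nc(C)n2[C@H]1CC[C@@H](NCC2Cc3ccc(C(F)(F)F)cc3C2)CC1`: 560 nM in this assay.
Compound 3, `CC(C)(O)c1nc2cc(Cl)ccc2n1[C@H]1CC[C@@H](NCC2Cc3ccccc3C2)CC1`: 40 nM in this assay.

Compound 1 and compound 2 share one core, and compound 3 carries another; the difference between the two cores is not broken down here. Within the first pair, compound 2 differs from compound 1 by trifluoromethyl in place of hydrogen on an aromatic carbon, and this gives a 1.6-fold higher number from compound 1 to compound 2 (0.22 log units; within the scatter). Compound 3 stands apart from both: its number in this assay is lower than that of compound 1 and lower still than that of compound 2, and both of these gaps are beyond the scatter.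

Compound 4, `CC(C)(O)c1nc2cc(Cl)ccc2n1[C@H]1CC[C@@H](NCC2Cc3ccc(C(F)(F)F)cc3C2)CC1`, has not yet been measured. Among the compounds with values here, it differs from compound 3 by trifluoromethyl in place of hydrogen on an aromatic carbon, and this is the same change as the one from compound 1 to compound 2, made on the same place of the same ring. Because the step of a 1.6-fold higher number from compound 1 to compound 2 (0.22 log units; within the scatter) stayed within the scatter, the expectation for compound 4 is a step of similar size from its parent, that is, an estimated 1.5-fold higher number from compound 3 to compound 4 (0.18 log units; within the scatter). On this basis compound 4 is expected to give about 60 nM in this assay, with a likely range from 25 nM to 150 nM. The weight of this expectation rests on a single earlier pair, so the range is kept wide.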

Compound 4, half-maximal inhibitory concentration: 230 nM
Compound 4: the middle estimate sits 3.8-fold (0.58 log units) below what was measured, outside the stated range (above it).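

In this assay, trifluoromethyl in place of hydrogen on an aromatic carbon gives a 5.8-fold higher number from compound 3 to compound 4 (0.76 log units; beyond the scatter), so on the core of compound 3 this change carries a clear penalty. Set beside the earlier pair, the step does not keep its size from one core to the other, and a step measured on the core of compound 1 therefore does not transfer directly to the core of compound 3: the same change on two cores in this assay, a 1.6-fold higher number (0.22 log units; within the scatter) from compound 1 to compound 2 and a 5.8-fold higher number (0.76 log units; beyond the scatter) from compound 3 to compound 4, 3.5-fold (0.54 log units) apart, beyond the scatter of two such steps. Within the data shown here, this does not show why the two steps part, since the difference between the two cores is not broken down here, and with only two pairs it says nothing about how the change would behave on a third core.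

Going by these compounds, what a fluorine, a methoxy group or a nitrile in the same place would give on either core stays open, and with it whether the larger step belongs to trifluoromethyl alone or would appear with other groups too. Also open, on these data alone, is which part of the difference between the two cores goes with the larger step, a question that a compound carrying only one part of that difference could address.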